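This account rests on a few compounds, and the source may have more. Where it says the series, first, only, none or still open, it means among the compounds named here.

Measured in a physicochemical assay for solubility; a higher number here means a more soluble compound, a lower number a less soluble compound:

Compound 1 `CNC(=O)c1cc(C(=O)NC2CC2)cn(Cc2ccc(F)cc2)c1=O`: >= 162 ug/mL
Compound 2 `CNC(=O)c1cc(C(=O)NCCC2CCOCC2)cn(Cc2ccccc2)c1=O`: >= 127 ug/mL
Compound 3 `CNC(=O)c1cc(C(=O)NC2CCC2)cn(Cc2cccc(NC)c2)c1=O`: >= 155 ug/mL

Each of these three results is a limit of the assay and not an exact number, so they cannot be ranked against one another. Compound 3 therefore has no exact position on the scale: its reading is the limit >= 155 ug/mL.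

Compound 4 `CNC(=O)c1cc(C(=O)NC2CCC2)cn(Cc2ccncc2)c1=O` differs from compound 3 at one place: pyridin-4-yl in place of 3-(methylamino)phenyl on a saturated chain carbon bound to an aromatic nitrogen. Here, pyridin-4-yl stands in place of 3-(methylamino)phenyl on a saturated chain carbon bound to an aromatic nitrogen. Cut one bond further out, the same change reads 3-(methylamino)benzyl to (pyridin-4-yl)methyl.

Among the measured compounds shown here, no pair of measured compounds shows what a single change does in this assay, so the limit of compound 3, >= 155 ug/mL, is the only anchor for this expectation. The expected step of an at least 1.0-fold lower number from compound 3 to compound 4 (0.01 log units; that floor lies within the scatter) has no clear direction and stays within the usual scatter. For compound 4 the estimate is 150 ug/mL, with an expected range of 100 ug/mL to 190 ug/mL.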

Compound 4, solubility: >= 118 ug/mL
Compound 4 gave a limit, no number; the forecaster's own chance of this, stated with the estimate: 80%; the middle value is on the limit's open side.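

In this assay compound 4 gives >= 118 ug/mL, which is a limit and not an exact number. Among the compounds shown here, compound 3 also has only a limit, so no step between compound 3 and compound 4 can be read. On these data alone, whether pyridin-4-yl in place of 3-(methylamino)phenyl raises, lowers or leaves the read-out unchanged stays open.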